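Pentyloxy to 4-hydroxybutyl on the chain

The source may report more compounds than this note shows. Statements on the series, on what has been measured and on what is new or still open speak of the compounds shown alone.

In a functional assay on Hs-578T cells (Homo sapiens) for antiproliferative activity (a higher number here means a weaker inhibitor of growth, a lower number a stronger inhibitor of growth), compound 3 `CCCCCOCCCCCCC/C=C1\CC(CO)(COC(=O)C(C)(C)C)OC1=O` gives 3 ug/mL, and compound 1 `COCCCCCCCCCCCCCCC/C=C1\CC(CO)(COC(=O)C(C)(C)C)OC1=O` gives 5.45 ug/mL. These two are separated by a 1.8-fold lower number from compound 1 to compound 3 (0.26 log units; within the scatter). Compound 2 `CCCCCCCCC(O)CCCCCC/C=C1\CC(CO)(COC(=O)C(C)(C)C)OC1=O` is reported only as a limit, > 10 ug/mL. For the measured compounds named here, the step that bears most on the next change is an at least 3.3-fold lower number from compound 2 to compound 3 (0.52 log units; beyond the scatter), since compound 2 is the only measured compound with a hydroxyl on the chain, though at a different place. In compound 4 `CC(C)(C)C(=O)OCC1(CO)C/C(=C\CCCCCCCCCCCO)C(=O)O1`, 4-hydroxybutyl stands in place of pentyloxy on a saturated chain carbon, seven bonds along the chain from a double-bonded chain carbon (4-hydroxybutyl in place of pentyloxy on a saturated chain carbon, seven bonds along the chain from a double-bonded chain carbon). A modest move to a higher number is expected, a 2.0-fold higher number from compound 3 to compound 4 (0.30 log units; within the scatter). For compound 4 the estimate is 6 ug/mL, with an expected range of 2.5 ug/mL to 14 ug/mL.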

Compound 4, concentration for 50% growth inhibition: > 10 ug/mL
Compound 4 ended at the assay's limit; the forecaster's own chance of this, stated with the estimate: 25%; middle value at least 1.6-fold (0.22 log units) away from the limit.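

In this assay, 4-hydroxybutyl in place of pentyloxy at this place gives a clear loss of growth inhibition: an at least 3.3-fold higher number from compound 3 to compound 4 (0.52 log units; beyond the scatter). The step of an at least 1.8-fold higher number from compound 1 to compound 4 (0.26 log units; that floor lies within the scatter) has a floor within the scatter, so only compound 3 is clearly separated from compound 4. Compound 4 gives > 10 ug/mL, which is a limit of the assay.

The step between compound 2 and compound 4 cannot be read, so the two hydroxyl-bearing chains stay unranked. As far as these compounds go, how an amine or a carboxylic acid in place of the hydroxyl would read at this place remains open.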